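From Iodo to tert-Butyl on a Chloroamide Aniline

The source may report more compounds than this note shows. Statements on the series, on what has been measured and on what is new or still open speak of the compounds shown alone.

Of the compounds shown here, three of a shared core have been measured in a functional assay on HT-29 cells (Homo sapiens) for antiproliferative activity, with a stated time of 48 h; a lower number here means a stronger inhibitor, a higher number a weaker inhibitor. Compound 1 `CC(C)(C)c1ccc(NC(=O)NCCCCl)cc1` gives 28000 nM, compound 2 `CC(C)(C)c1ccc(NC(=O)CCl)cc1` gives 15000 nM, and compound 3 `O=C(CCCl)Nc1ccc(I)cc1` gives 18000 nM. Compound 3 thus sits in the middle of the three numbers, and both compound 2 and compound 1 lie within the usual scatter of it. Going by the values given here, the only single-point step among the measured compounds, a 1.9-fold lower number from compound 1 to compound 2 (0.27 log units; within the scatter), is likewise within the scatter, so none of the measured changes has so far shifted the read-out appreciably.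

Compound 4 `CC(C)(C)c1ccc(NC(=O)CCCl)cc1` remains to be measured. It differs from compound 3 by tert-butyl in place of iodo on an aromatic carbon. Among the compounds with values here, no measured step exchanges these two groups directly, but the two measured compounds carrying them on the same kind of carbon give numbers within the scatter of each other: compound 2 with tert-butyl gives 15000 nM, while compound 3 with iodo gives 18000 nM. The step expected in this assay is therefore a 1.1-fold lower number from compound 3 to compound 4 (0.05 log units; within the scatter), nothing beyond the scatter in either direction. Compound 4 is accordingly estimated at 16000 nM, with a range from 6000 nM to 45000 nM.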

Compound 4, half-maximal inhibitory concentration: 88000 nM
Estimate against measurement, compound 4: 5.5-fold (0.74 log units) below; measured number above the stated range.
By their numbers in this assay, from the lowest: compounds 2, 3 and 1 (each within the scatter of the next); then compound 4.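

In this assay, going by these compounds alone, tert-butyl in place of iodo on the aromatic carbon gives the first change at this position that lies beyond the scatter (a 4.9-fold higher number from compound 3 to compound 4 (0.69 log units; beyond the scatter)), so this exchange is not neutral when 2-chloroethyl stands on the carbonyl carbon. With tert-butyl held in place, the group on the carbonyl carbon also proves to matter: compound 4 stands apart both from the chloromethyl compound (a 5.9-fold higher number from compound 2 to compound 4 (0.77 log units; beyond the scatter)) and from the (3-chloropropyl)amino compound (a 3.1-fold higher number from compound 1 to compound 4 (0.50 log units; beyond the scatter)), although those two remain within the scatter of each other (a 1.9-fold lower number from compound 1 to compound 2 (0.27 log units; within the scatter)). No measurement available here accounts for these steps.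

The compounds shown leave open whether the tert-butyl to iodo exchange would produce a step of similar size with chloromethyl or (3-chloropropyl)amino on the carbonyl carbon, and so whether the step belongs to the aromatic position alone or to this particular pairing of groups. They also leave open how a methoxy group or an amine on the same aromatic carbon, or a longer chloroalkyl chain on the carbonyl carbon, would place a compound relative to compound 3 and compound 4.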